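A few compounds are considered here, and "the series" means these few. Any claim that something is new, unique, unknown or untested is made for them only; others in the source may bear on it.

Measured so far:
compound 1, `Fc1ccc(Oc2ccc(/C=N/NC(=S)Nc3ccc(Cl)cc3)cc2)cc1`: 5.84
compound 2, `Fc1ccc(Oc2ccc(/C=N/NC(=S)Nc3ccc(Br)cc3)cc2)cc1`: 5.82
compound 3, `Fc1ccc(NC(=S)N/N=C/c2ccc(Oc3ccc4ccccc4c3)cc2)cc1`: 6.2

In a physicochemical assay for lipophilicity, in phosphate buffer, measured as octanol-water partition, with a stated time of 24 h (on this read-out lower numbers stand for lower lipophilicity and higher numbers for higher lipophilicity), compound 1 stands second highest of the three. Its nearest neighbour is compound 2, with a number 0.02 log units lower from compound 1 to compound 2 (within the scatter). Compound 3 gives 6.2, and that value sits beyond the scatter from the value of compound 1. The unmeasured compound 4, `Cc1ccc(Oc2ccc(/C=N/NC(=S)Nc3ccc(Cl)cc3)cc2)cc1`, differs from compound 1 by methyl in place of fluoro on an aromatic carbon. For the measured compounds named here, no measured step bears directly on this change; the only measured step exchanges one halogen for another and stays within the scatter. For compound 4 a modest rise is expected, a number 0.36 log units higher from compound 1 to compound 4 (beyond the scatter), somewhat beyond the scatter. Compound 4 is therefore estimated at 6.2, within a range from 5.8 to 6.6.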

Compound 4, partition coefficient: 5.97
The estimate for compound 4 lay 0.23 log units above the measured number; measured number inside the range.
By their numbers in this assay, from the lowest: compounds 2, 1, 4 and 3 (each within the scatter of the next, the first and the last beyond it).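

In this assay, methyl in place of fluoro at this position, para to a large group, gives a number 0.13 log units higher from compound 1 to compound 4 (within the scatter), so this exchange leaves the read-out within the scatter. For the compounds shown here, the one earlier step exchanged only one halogen for another at a different place, whereas here a carbon group replaces a halogen. Nothing at hand gives a reason for this result.

On these data alone, whether an amine, a carboxylic acid or a longer chain at this position would also stay within the scatter remains open. So does whether methyl in place of fluoro would read the same in other compounds.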